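The source may hold more compounds than are shown below. What is called first, only, known or untested is meant among the compounds shown, and "the series" means these compounds.

Compound 2, with the structure `Oc1ccc(-c2cc(-c3ccsc3)cc(-c3ccccc3O)n2)cc1`, is one of two compounds already measured. In a functional assay on T47D cells (Homo sapiens) for cytotoxicity, read by CCK-8 assay (a lower number here means a stronger inhibitor, a higher number a weaker inhibitor), compound 2 gives > 50000 nM, which is a limit of the assay rather than a number. Compound 1, with the structure `Oc1ccc(-c2cc(-c3cccs3)cc(-c3ccccc3O)n2)cc1`, is the other measured compound. In this assay compound 1 gives > 50000 nM, again a limit. Among the compounds with values here, the only measured step, a step that the two limits leave unreadable from compound 1 to compound 2, is therefore unreadable in size, and the limit of > 50000 nM in this assay, at which 2 of the 2 values shown sit, is all the evidence there is. Compound 3, with the structure `Oc1ccc(-c2cc(-c3ccsc3)cc(-c3ccc(O)cc3)n2)cc1`, differs from compound 2 by 4-hydroxyphenyl in place of 2-hydroxyphenyl on an aromatic carbon. Within the data shown here, no measured step bears on this change, so there is no ground for expecting movement in either direction in this assay beyond the scatter. Compound 3 is therefore estimated at 60000 nM, within 20000 nM to 200000 nM, which as a step means a step that the limit leaves unreadable from compound 2 to compound 3, with a strong chance that only a limit is reported.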

Compound 3, half-maximal inhibitory concentration: 1770 nM
Compound 3: middle estimate off by 34-fold (1.53 log units), on the high side; measured number outside the range, below it.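

Moving the hydroxyl around the phenyl group on the aromatic carbon next to the ring nitrogen, with the same atoms joined differently, gives the first readable change in this assay: an at least 28-fold lower number from compound 2 to compound 3 (1.45 log units; beyond the scatter). This shows that the result at this position depends on whether a 2-hydroxyphenyl or a 4-hydroxyphenyl group sits there, which the earlier pair of compounds could not show, as the step between its two thiophene isomers cannot be read. Compound 1 and compound 2 remain at a limit of the assay, not a number: the limit of > 50000 nM in this assay, at which 2 of the 3 values shown sit.

As far as these compounds go, it remains open whether a 3-hydroxyphenyl group, or a 4-aminophenyl or 4-methoxyphenyl group, at this carbon would give a similar value. Also open, from the compounds shown here alone, is whether 4-hydroxyphenyl has the same effect when thiophen-2-yl replaces thiophen-3-yl.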